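Compound 1 to compound 4: methyl to propyl

A few compounds are considered here, and "the series" means these few. Any claim that something is new, unique, unknown or untested is made for them only; others in the source may bear on it.

Compound 1 `Cc1ccc(OS(=O)(=O)c2ccc(N3CCN(C)C3=O)cc2)c(C)c1` gives 2500 nM in a functional assay on MCF7 cells (Homo sapiens) for antiproliferative activity, read by sulforhodamine B assay, with a stated time of 48 h (a lower number here means a stronger inhibitor, a higher number a weaker inhibitor), and lies within the scatter of compound 3 `CN1CCN(c2ccc(S(=O)(=O)Oc3cccc(Cl)c3)cc2)C1=O` at 2200 nM in the same measurement. Compound 2 `CN1CCN(c2ccc(S(=O)(=O)Oc3cccc(F)c3)cc2)C1=O` stands at > 100000 nM which is a limit of the assay. Compound 4 `CCCN1CCN(c2ccc(S(=O)(=O)Oc3ccc(C)cc3C)cc2)C1=O` differs by ethyl in place of hydrogen on a saturated chain carbon bound to an amide-type nitrogen in a ring so that methyl becomes propyl. For the measured compounds named here, no measured step touches that place. All three concern the group on an oxygen: a 1.1-fold lower number from compound 1 to compound 3 (0.06 log units; within the scatter) stays within the scatter, while an at least 40-fold higher number from compound 1 to compound 2 (1.60 log units; beyond the scatter) and an at least 45-fold lower number from compound 2 to compound 3 (1.65 log units; beyond the scatter) are large. These steps give no direction for the new change, so none beyond the scatter is expected, though with wide uncertainty. The expected step is a 1.2-fold higher number from compound 1 to compound 4 (0.08 log units; within the scatter) in this assay on this reasoning. The estimate for compound 4 is 3000 nM with an expected range of 700 nM to 15000 nM for now.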

Compound 4, half-maximal inhibitory concentration: 1500 nM
Estimate against measurement, compound 4: 2.0-fold (0.30 log units) above, and the stated range covers the measured number.
By their numbers in this assay, from the lowest: compounds 4, 3 and 1 (each within the scatter of the next). At a limit, above all of these: compound 2.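

In this assay, ethyl in place of hydrogen on a saturated chain carbon bound to an amide-type nitrogen in a ring gives a 1.7-fold lower number from compound 1 to compound 4 (0.22 log units; within the scatter) with the 2,4-dimethylphenyl on the oxygen unchanged. For the compounds shown here, this is the only step at this place, as all earlier steps concern the group on an oxygen, and it shows that propyl can replace methyl here without a step beyond the scatter. Nothing shown gives a cause for this step.

As far as these compounds go, whether this also holds with the 3-chlorophenyl of compound 3 remains open. So does the effect of a longer chain, a benzyl group or an amine at this place.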